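Cycloheptyl Replaces an Aryl Ring on the Piperazine Nitrogen

The source may hold more compounds than are shown below. What is called first, only, known or untested is meant among the compounds shown, and "the series" means these compounds.

The measured compounds are:
Compound 1 `Nc1scc(CN2CCN(c3cc(Cl)cc(Cl)c3)CC2)c1C(=O)c1ccc(Cl)cc1` gives -22%.
Compound 2 `Nc1scc(CN2CCN(c3cccc(C(F)(F)F)c3)CC2)c1C(=O)c1ccc(Cl)cc1` gives -30%.
Compound 3 `Nc1scc(CN2CCN(c3ccc(C(F)(F)F)cc3)CC2)c1C(=O)c1cccc(C(F)(F)F)c1` gives -11%.

All three were tested in a functional assay on CHO cells with adenosine receptor A1 (Homo sapiens) as the target, read by cAMP accumulation and immunoassay, with a stated time of 6 min, tested at 0.1 uM; a higher number here means a weaker effect of the compound at the concentration tested, a lower number a stronger effect. Compound 2 has the lowest number of the three; compound 1 is nearest, only a little higher and within the scatter, while compound 3 is furthest, a difference that lies beyond the scatter.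

The unmeasured compound 4 `Nc1scc(CN2CCN(C3CCCCCC3)CC2)c1C(=O)c1ccc(Cl)cc1` differs from compound 2 in one place: cycloheptyl in place of 3-(trifluoromethyl)phenyl on an amine nitrogen in a ring. Among the compounds with values here, the only measured step that touches this position is the one from compound 1 to compound 2, a number 8 percentage points lower from compound 1 to compound 2 (within the scatter), and it swaps one aromatic ring for another on the same nitrogen, a change which stayed within the scatter. Within the data shown here, no measured pair shows what happens when the aromatic ring gives way to a saturated ring, so that step offers only weak guidance. The expectation is therefore a step of uncertain direction, most likely not beyond the scatter, with a wide range on either side.

For compound 4 the estimate is -15%, within a range from -45% to 15%, which is expected to mean a step of a number 15 percentage points higher from compound 2 to compound 4 (beyond the scatter).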

Compound 4, a percentage reported as activity, at one concentration (the size of the read-out at that concentration, not a potency): 13%
Beside the measured number, compound 4's estimate is 28 percentage points below it; low and high end bracket the measured number.
By their numbers in this assay, from the lowest: compounds 2 and 1 (each within the scatter of the next); then compound 3; then compound 4.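

In this assay, within the data shown here, the group on the amine nitrogen of the six-membered ring turns out to matter far more than the one earlier step at this position could show. Swapping one aromatic ring for another gave only a number 8 percentage points lower from compound 1 to compound 2 (within the scatter) and stayed within the scatter, whereas cycloheptyl in place of 3-(trifluoromethyl)phenyl gives a number 43 percentage points higher from compound 2 to compound 4 (beyond the scatter) and cycloheptyl in place of 3,5-dichlorophenyl gives a number 35 percentage points higher from compound 1 to compound 4 (beyond the scatter) as two large steps in the same direction, towards a weaker effect at the concentration tested. The number also changes sign, since compound 1 at -22% and compound 2 at -30% are negative while compound 4 at 13% is positive.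

The compounds shown leave open whether the large steps follow from the loss of the aromatic ring or from the size of the saturated ring, a question that a cyclohexyl or cyclopentyl group, or an unsubstituted phenyl ring, on the same nitrogen could help to settle. Nothing available here explains why cycloheptyl behaves so differently from the two substituted aromatic rings at this position.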